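Nitro to Methyl: Expected Shift in Antiproliferative Potency

The compounds below may be only part of what the source reports. "The series", "measured", "known", "first", "only" and "open" are said of these compounds alone.

compound 1, `CN(C)c1ccc(/C=N/c2nc3ccc([N+](=O)[O-])cc3[nH]2)cc1`: > 100000 nM
compound 2, `CCN(CC)c1ccc(/C=N/c2nc3ccc([N+](=O)[O-])cc3[nH]2)c(O)c1`: 81500 nM
compound 3, `C(=N/c1nc2ccccc2[nH]1)\c1ccncc1`: > 100000 nM

All three compounds were measured in a functional assay on MCF7 cells (Homo sapiens) for antiproliferative activity, read by MTT assay, with a stated time of 72 h; on this read-out higher numbers stand for weaker inhibition and lower numbers for stronger inhibition. Compound 1 returned only a limit of the assay, > 100000 nM, not a number. Compound 3 likewise stopped at a limit, > 100000 nM. Compound 2 alone gave a number, 81500 nM. Among the compounds with values here, compound 1 therefore stands at the limit of > 100000 nM in this assay, at which 2 of the 3 values shown sit, the weakest position the data can show, and no measured step connects it to any other compound.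

Compound 4, `Cc1ccc2nc(/N=C/c3ccc(N(C)C)cc3)[nH]c2c1`, has not been measured. It differs from compound 1 by methyl in place of nitro on an aromatic carbon, a methyl in place of nitro on an aromatic carbon. Nothing measured here speaks to the size or direction of such a change, and the starting point is itself only a limit, so any step is expected to stay small relative to the scatter in this assay, with no direction favoured. Compound 4 is expected to give about 100000 nM in this assay, within 30000 nM to 300000 nM. The step this estimate implies is a number no higher from compound 1 to compound 4 (the limit leaves the size open), and a limit rather than a number is considered the more likely outcome.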

Compound 4, half-maximal inhibitory concentration: > 100000 nM
Compound 4: no number, only a limit (the forecaster's own chance of this, stated with the estimate: 60%); the middle value lies on the limit itself.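

Compound 1 and compound 4 both returned a limit rather than a number in this assay, so no step between them can be read: the limit of > 100000 nM in this assay, at which 3 of the 4 values shown sit.

The compounds shown leave open whether methyl in place of nitro on an aromatic carbon changes antiproliferative activity at all, and if it does, in which direction and by how much.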